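Chloro to methyl on the aryl ring of compound 1

The compounds below may be only part of what the source reports. "The series", "measured", "known", "first", "only" and "open" are said of these compounds alone.

Among the compounds with values here, compound 1 `CC(=O)OC[C@H]1O[C@H](OC[C@@H](Cn2cc(CN(c3nc(-c4ccc(Cl)cc4)no3)C3CCCCC3)nn2)OC(C)=O)C=C[C@@H]1OC(C)=O` is the less tolerated of the two compounds measured so far: in an ADME assay on RAW264.7 cells (Mus musculus) for cytotoxicity, read by MTT assay, with a stated time of 48 h (a higher number here means that more compound is tolerated, a lower number that less compound is tolerated), compound 1 gives 35.5 ug/mL, while compound 2 `CC(=O)OC[C@H]1O[C@H](OC[C@@H](CN=[N+]=[N-])OC(C)=O)C=C[C@@H]1OC(C)=O` gives 106 ug/mL, a gap beyond the scatter. Compound 3 `CC(=O)OC[C@H]1O[C@H](OC[C@@H](Cn2cc(CN(c3nc(-c4ccc(C)cc4)no3)C3CCCCC3)nn2)OC(C)=O)C=C[C@@H]1OC(C)=O` differs from compound 1 by methyl in place of chloro on an aromatic carbon, the new group sitting para to a large group on the same ring. Within the data shown here, no measured pair shows this exchange, so the step of a 1.1-fold higher number from compound 1 to compound 3 (0.05 log units; within the scatter) is expected to be small, in either direction, and not beyond the scatter. Compound 3 is therefore estimated at 40 ug/mL, within 20 ug/mL to 80 ug/mL.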

Compound 3, half-maximal cytotoxic concentration: 45.3 ug/mL
Compound 3: middle estimate off by 1.1-fold (0.05 log units), on the low side; measured number inside the range.
By their numbers in this assay, from the lowest: compounds 1 and 3 (each within the scatter of the next); then compound 2.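

The exchange of chloro for methyl on this aromatic carbon gives a 1.3-fold higher number from compound 1 to compound 3 (0.11 log units; within the scatter), so this assay does not tell the two groups apart at this place. Within the data shown here, this is the first measured exchange on this ring, and it shows that the number holds with either group in place. Nothing measured here offers an explanation for this result.

From the compounds shown here alone, whether an amine, a carboxylic acid or a longer chain on the same carbon would move the number beyond the scatter remains open. So does whether the same exchange would behave alike on a different core.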